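Anilinoquinoline-type analogues: estimating compound 4 from three measurements

A few compounds are considered here, and "the series" means these few. Any claim that something is new, unique, unknown or untested is made for them only; others in the source may bear on it.

Measured compounds in a functional assay on UACC-257 cells (Homo sapiens) for inhibition, read by sulforhodamine B assay, with a stated time of 48 h; on this read-out lower numbers stand for stronger inhibition of growth and higher numbers for weaker inhibition of growth:
compound 1, `CN1CCN(CCCOc2cccc3nc(Nc4ccc(Cl)c(C(F)(F)F)c4)ccc23)CC1`, gives 1720 nM
compound 2, `CC(C)c1ccc(Nc2ccc3c(OCCCN4CCN(C)CC4)cccc3n2)cc1`, gives 5650 nM
compound 3, `CN1CCN(CCCOc2cccc3nc(Nc4ccc(F)c(F)c4)ccc23)CC1`, gives 660 nM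

Compound 3 stands at the lowest number of the three; the nearest is compound 1, shown by a 2.6-fold lower number from compound 1 to compound 3 (0.42 log units; beyond the scatter), and the furthest is compound 2, shown by an 8.6-fold lower number from compound 2 to compound 3 (0.93 log units; beyond the scatter). Compound 4, `CN1CCN(CCCOc2cccc3nc(Nc4cc(Cl)cc(Cl)c4)ccc23)CC1`, has not yet been measured in this assay. It differs from compound 3 by 3,5-dichlorophenyl in place of 3,4-difluorophenyl on a nitrogen on an aromatic ring.

Among the compounds with values here, no measured step swaps one halogenated aryl group for another of the same kind, so the nearest guides are the aryl exchanges already seen: a 2.6-fold lower number from compound 1 to compound 3 (0.42 log units; beyond the scatter) and a 3.3-fold higher number from compound 1 to compound 2 (0.52 log units; beyond the scatter), both modest. Exchanging the aryl group on the nitrogen has so far moved the read-out only modestly in either direction, and compound 3 sits at the low end of the range. Compound 4 is therefore expected to give a number close to, or somewhat higher than, that of compound 3, a step of a 1.5-fold higher number from compound 3 to compound 4 (0.18 log units; within the scatter). The estimate for compound 4 in this assay is 1000 nM, with a range from 350 nM to 3000 nM.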

Compound 4, concentration for 50% growth inhibition: 1970 nM
Estimate against measurement, compound 4: 2.0-fold (0.29 log units) below; the range from low to high includes it.
By their numbers in this assay, from the lowest: compound 3; then compounds 1 and 4 (each within the scatter of the next); then compound 2.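

In this assay, the step of a 3.0-fold higher number from compound 3 to compound 4 (0.47 log units; beyond the scatter) shows that the low number of the difluorinated analogue does not carry over to every dihalogenated aryl group on this nitrogen, even though the entering and leaving groups match in heavy-atom count. The step of a 1.1-fold higher number from compound 1 to compound 4 (0.06 log units; within the scatter) does not separate 3,5-dichlorophenyl from 4-chloro-3-(trifluoromethyl)phenyl, while a 2.9-fold lower number from compound 2 to compound 4 (0.46 log units; beyond the scatter) sets 3,5-dichlorophenyl apart from 4-isopropylphenyl, so among the compounds shown only 3,4-difluorophenyl gives a lower number than these two chlorinated groups. No measurement at hand explains why the read-out moves with this exchange.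

This exchange alters both the halogen and the places it occupies on the ring, and the compounds shown do not separate the two. On these data alone, how an unsubstituted phenyl, or a phenyl carrying a nitrile or an amine, would read on this nitrogen also stays open.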